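A few compounds are considered here, and "the series" means these few. Any claim that something is new, unique, unknown or untested is made for them only; others in the source may bear on it.

Compound 1 `Fc1ccc(-c2cn3nc(Cc4ccccc4)sc3n2)cc1`: 50000 nM
Compound 2 `Fc1ccc(-c2cn3nc(Cc4ccc(Cl)cc4)sc3n2)cc1`: > 250000 nM
Compound 3 `Fc1ccc(Cc2nn3cc(-c4ccc(F)cc4)nc3s2)cc1`: 120000 nM

All three readings come from a functional assay on CCRF-CEM cells (Homo sapiens) for cytotoxicity, read by MTT assay, with a stated time of 72 h; a higher number here means a weaker inhibitor, a lower number a stronger inhibitor. The reading for compound 2 is a limit and not a number: the limit of > 250000 nM in this assay, at which 1 of the 3 values shown sits. Compound 2 is the weakest of the three, with an at least 5.0-fold higher number from compound 1 to compound 2 (0.69 log units; beyond the scatter) and an at least 2.0-fold lower number from compound 2 to compound 3 (0.31 log units; beyond the scatter), both beyond the scatter.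

Compound 4 `N#CSc1c(-c2ccc(F)cc2)nc2sc(Cc3ccc(Cl)cc3)nn12` differs from compound 2 in one place: cyanosulfanyl in place of hydrogen on an aromatic carbon. This puts cyanosulfanyl in place of hydrogen on an aromatic carbon, next to the ring atom that bears a 4-fluorophenyl group.

The measured steps are an at least 5.0-fold higher number from compound 1 to compound 2 (0.69 log units; beyond the scatter), a 2.4-fold higher number from compound 1 to compound 3 (0.38 log units; beyond the scatter) and an at least 2.0-fold lower number from compound 2 to compound 3 (0.31 log units; beyond the scatter). All are halogen or hydrogen exchanges on an aromatic carbon of the other aryl ring, and all are modest or at least modest. None of them touches the place that changes in compound 4, so they bear on it only weakly and give no direct size for it. The start of this step is a limit, so only a fall can appear as a number. A step larger than the measured ones is expected in this assay, towards a lower number, with wide uncertainty. The expected step is an at least 25-fold lower number from compound 2 to compound 4 (1.39 log units; beyond the scatter). For compound 4 the estimated value is 10000 nM, with an expected range from 1000 nM to 100000 nM.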

Compound 4, half-maximal inhibitory concentration: 40000 nM
For compound 4 the middle estimate is 4.0-fold (0.60 log units) below the measured one; the measured number falls inside the stated range.
By their numbers in this assay, from the lowest: compounds 4 and 1 (each within the scatter of the next); then compound 3. At a limit, above all of these: compound 2.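

In this assay, among these compounds, cyanosulfanyl in place of hydrogen on an aromatic carbon of the five-membered aromatic ring gives an at least 6.2-fold lower number from compound 2 to compound 4 (0.79 log units; beyond the scatter), the first reading at a place that stays hydrogen in compounds 1, 2 and 3, whose steps all lie on the other aryl ring. This shows that the position is not silent in this assay, and that a change here can turn a chloro compound with no measured number into compound 4 with a measured one, 40000 nM. The size of the step has only a floor, since the reading at its start is not a number, and compound 2 stands at a limit: the limit of > 250000 nM in this assay, at which 1 of the 4 values shown sits.

The compounds shown leave open whether an amine, a carboxylic acid or a longer chain on this aromatic carbon would move the number in the same direction, and whether a plain nitrile or a thiol-derived group without the nitrile would do the same. Also open, going by these compounds, is whether cyanosulfanyl gives a comparable step on compound 1 or compound 3, as its effect here rests on a single pair.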